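Chain length and acid group in a guinea-pig ileum series

The source may report more compounds than this note shows. Statements on the series, on what has been measured and on what is new or still open speak of the compounds shown alone.

Measured compounds:
compound 1 `CCCc1c(OCCCCCCCCCCc2nn[nH]n2)ccc(C(C)=O)c1O` — 3160 nM
compound 2 `CCCc1c(OCCCCCCCCCC(=O)O)ccc(C(C)=O)c1O` — 794 nM
compound 3 `CCCc1c(OCCCCCCCCCc2nn[nH]n2)ccc(C(C)=O)c1O` — 251 nM

In a functional assay (ileum) with Cavia porcellus as the target (on this read-out lower numbers stand for stronger inhibition and higher numbers for weaker inhibition), compound 2 gives 794 nM, the second highest of the three numbers; compound 3 lies nearest with a 3.2-fold lower number from compound 2 to compound 3 (0.50 log units; beyond the scatter), compound 1 furthest with a 4.0-fold lower number from compound 1 to compound 2 (0.60 log units; beyond the scatter).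

Compound 4 `CCCc1c(OCCCCCCCCc2nn[nH]n2)ccc(C(C)=O)c1O` is not yet measured. Relative to compound 2 the change is 2H-tetrazol-5-yl in place of carboxymethyl on a saturated chain carbon, eight bonds along the chain from an oxygen on an aromatic ring.

Among the measured compounds shown here, two measured steps bear on it. Replacing the acid by the tetrazole at the same chain position gave a 3.2-fold lower number from compound 2 to compound 3 (0.50 log units; beyond the scatter). Taking one chain carbon out of the tetrazole series gave a 13-fold lower number from compound 1 to compound 3 (1.10 log units; beyond the scatter). For the measured compounds named here, compound 4 combines both moves, so a lower number in this assay is expected; how far the shortening carries is uncertain, as only one such step is known.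

Compound 4 is therefore estimated at 160 nM, within 40 nM to 630 nM, corresponding to an expected step of a 5.0-fold lower number from compound 2 to compound 4 (0.70 log units; beyond the scatter).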

Compound 4, half-maximal inhibitory concentration: 316 nM
For compound 4 the middle estimate is 2.0-fold (0.30 log units) below the measured one; the range from low to high includes it.
By their numbers in this assay, from the lowest: compounds 3 and 4 (each within the scatter of the next); then compound 2; then compound 1.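

In this assay the gain seen on removing one chain carbon from compound 1 does not continue with a further shortening in the tetrazole series (a 1.3-fold higher number from compound 3 to compound 4 (0.10 log units; within the scatter)), while the longest tetrazole chain remains well apart (a 10-fold lower number from compound 1 to compound 4 (1.00 log units; beyond the scatter)). So, among these three tetrazoles, the sensitivity to chain length lies at the long end, and the two shorter chains cannot be told apart. The 2H-tetrazol-5-yl compound on the shorter chain also keeps an advantage over the carboxylic acid when carboxymethyl is the group replaced (a 2.5-fold lower number from compound 2 to compound 4 (0.40 log units; beyond the scatter)), and no data on hand account for any of these steps.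

From the compounds shown here alone, whether the level held by compound 3 and compound 4 persists on a still shorter chain remains open. Also open, going by these compounds, is how a sulfonic acid or a hydroxamic acid at the chain end would compare with the tetrazole.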